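Swapping Furan for Thiophene on the Pyridine Side

A few compounds are considered here, and "the series" means these few. Any claim that something is new, unique, unknown or untested is made for them only; others in the source may bear on it.

- Compound 1 (`NC1CCC(Nc2nc(NCc3ccc(-c4ccco4)cc3)c3ncn(C4CCCC4)c3n2)CC1`) at 85 nM
- Compound 2 (`NC1CCC(Nc2nc(NCc3ccc(-c4ccco4)nc3)c3ncn(C4CCCC4)c3n2)CC1`) at 33 nM

In a functional assay on MCF7 cells (Homo sapiens) for inhibition, with a stated time of 72 h (a higher number here means a weaker inhibitor, a lower number a stronger inhibitor), compound 2 holds the lower of the two numbers, 33 nM, which makes it the stronger inhibitor of the pair. Compound 3 (`NC1CCC(Nc2nc(NCc3ccc(-c4cccs4)nc3)c3ncn(C4CCCC4)c3n2)CC1`) changes one group: thiophen-2-yl in place of furan-2-yl on an aromatic carbon. In short, thiophen-2-yl takes the place of furan-2-yl on an aromatic carbon. Among the measured compounds shown here, only one measured step bears on this, and only loosely: a 2.6-fold lower number from compound 1 to compound 2 (0.41 log units; beyond the scatter). That modest step changed the ring carrying the furan-2-yl, not the furan-2-yl itself. For the measured compounds named here, no measured pair shows the new exchange, so no step beyond the scatter is expected in this assay, in either direction. The expected change is a 1.1-fold higher number from compound 2 to compound 3 (0.03 log units; within the scatter). For compound 3 the estimate is 35 nM, with an expected range from 14 nM to 90 nM.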

Compound 3, half-maximal inhibitory concentration: 92 nM
Compound 3: middle estimate off by 2.6-fold (0.42 log units), on the low side; the whole stated range lies below it.
By their numbers in this assay, from the lowest: compound 2; then compounds 1 and 3 (each within the scatter of the next).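

Replacing furan-2-yl with thiophen-2-yl keeps the counts of heavy atoms, hydrogen-bond donors and acceptors the same, yet this assay records a 2.8-fold higher number from compound 2 to compound 3 (0.45 log units; beyond the scatter) for this exchange, so this position on the ring distinguishes the two groups. The other new step is a 1.1-fold higher number from compound 1 to compound 3 (0.03 log units; within the scatter) and this shows that the edge compound 2 held over compound 1 is not kept once thiophen-2-yl is in place. Nothing available here accounts for the gap between the furan-2-yl and thiophen-2-yl compounds.

The compounds shown leave open whether furan-2-yl is unusually favourable at this position or thiophen-2-yl unusually poor, a question that a plain phenyl, a furan-3-yl or an oxazol-2-yl group could help to settle. Also open, from the compounds shown here alone, is how thiophen-2-yl would behave on the phenyl ring of compound 1.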